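Acyl variation in the series: difluorinated benzamide

A few compounds are considered here, and "the series" means these few. Any claim that something is new, unique, unknown or untested is made for them only; others in the source may bear on it.

In an assay on CHO-K1 cells for displacement of a labelled ligand from prostaglandin E2 receptor EP1 subtype (Homo sapiens) (on this read-out higher numbers stand for weaker inhibition and lower numbers for stronger inhibition), compound 3 `Cc1cc(NC(=O)c2ccccc2)nn1Cc1cc(Cl)ccc1OCc1ccccc1` gives 15.9 nM, the second highest of the three numbers recorded. Compound 2 `Cc1cc(NC(=O)CC(C)(C)C)nn1Cc1cc(Cl)ccc1OCc1ccccc1` gives 10 nM, and the gap a 1.6-fold higher number from compound 2 to compound 3 (0.20 log units; within the scatter) lies within the scatter. Compound 1 `CC(=O)Nc1cc(C)n(Cc2cc(Cl)ccc2OCc2ccccc2)n1` gives 316 nM, with a 20-fold lower number from compound 1 to compound 3 (1.30 log units; beyond the scatter) and a 32-fold lower number from compound 1 to compound 2 (1.50 log units; beyond the scatter) both large. Compound 4 `Cc1cc(NC(=O)c2c(F)cccc2F)nn1Cc1cc(Cl)ccc1OCc1ccccc1` carries 2,6-difluorophenyl in place of phenyl on a carbonyl carbon. Going by the values given here, no measured step alters a benzoyl ring itself; the steps that bear on it exchange the whole acyl group, where the large steps away from acetyl start from compound 1, while the neopentyl-to-phenyl exchange a 1.6-fold higher number from compound 2 to compound 3 (0.20 log units; within the scatter) stays within the scatter. A step within the scatter is therefore expected in this assay, a 1.3-fold lower number from compound 3 to compound 4 (0.12 log units; within the scatter). Compound 4 is estimated at 12 nM, range 4 nM to 40 nM.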

Compound 4, half-maximal inhibitory concentration in the prostaglandin E2 receptor EP1 subtype assay: 12.6 nM
Compound 4: middle estimate off by 1.1-fold (0.02 log units), on the low side; the measured number falls inside the stated range.
By their numbers in the prostaglandin E2 receptor EP1 subtype assay, from the lowest: compounds 2, 4 and 3 (each within the scatter of the next); then compound 1.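

In the prostaglandin E2 receptor EP1 subtype assay, the step on the benzoyl ring itself, a 1.3-fold lower number from compound 3 to compound 4 (0.10 log units; within the scatter), shows that 2,6-difluorophenyl and phenyl on this carbonyl carbon cannot be told apart. In the prostaglandin E2 receptor EP1 subtype assay, a 1.3-fold higher number from compound 2 to compound 4 (0.10 log units; within the scatter) also stays within the scatter, whereas a 25-fold lower number from compound 1 to compound 4 (1.40 log units; beyond the scatter) leaves the acetyl compound 1 apart from the other three. In a physicochemical assay for lipophilicity, at pH 7.4 (a lower number here means a more polar compound, a higher number a more lipophilic compound), compound 3 gives > 3.7, which is a limit of the assay and not a number. In the physicochemical assay compound 4 gives > 3.7, which is likewise a limit of the assay and not a number. In the physicochemical assay, the step between compound 3 and compound 4 cannot be read, since both values are limits: the limit of > 3.7 in the physicochemical assay, at which 2 of the 2 values shown sit.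

Open, on these data alone, is whether an amine or a carboxylic acid on the benzoyl ring would hold the number in the prostaglandin E2 receptor EP1 subtype assay and give a readable value in the physicochemical assay.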